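Same Atoms, One Stereocentre Left Undefined

The source may report more compounds than this note shows. Statements on the series, on what has been measured and on what is new or still open speak of the compounds shown alone.

Among the measured compounds shown here, in a toxicity assay on HEK-293T cells (Homo sapiens) for cytotoxicity, read by MTT assay, with a stated time of 72 h (on this read-out higher numbers stand for weaker inhibition and lower numbers for stronger inhibition), compound 1 `CN(C)CCCCCn1c2c(c3ccccc31)C(=O)c1c[n+]([O-])c3ccccc3c1C2=O` gives 70 nM, and compound 2 `O=C1c2c[n+]([O-])c3ccccc3c2C(=O)c2c1c1ccccc1n2Cc1cn(C[C@H](O)CO)nn1` gives 8880 nM, the higher of the two numbers measured so far. For the measured compounds named here, the only measured step is a 130-fold higher number from compound 1 to compound 2 (2.10 log units; beyond the scatter). It is large, and it comes with 1-(2,3-dihydroxypropyl)-1H-1,2,3-triazol-4-yl in place of 4-(dimethylamino)butyl. Compound 3 `O=C1c2c[n+]([O-])c3ccccc3c2C(=O)c2c1c1ccccc1n2Cc1cn(CC(O)CO)nn1` involves a far smaller change: the two compounds have the same atoms and bonds; at least one stereo element is drawn with a configuration in one of them and without one in the other: 1 of 1 stereo elements differ; a stereocentre at a saturated chain carbon is drawn S in compound 2 and without a configuration in compound 3. Going by the values given here, nothing leaves and nothing enters, so the one measured step, which swaps a whole group, offers little guidance here, and no measured pair tests a stereocentre. The expectation therefore stays close to compound 2 at 8880 nM, with no step beyond the scatter expected in this assay. The expected step is a 1.0-fold lower number from compound 2 to compound 3 (0.02 log units; within the scatter). For compound 3 the estimate is 8500 nM, with an expected range from 4000 nM to 18000 nM.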

Compound 3, half-maximal inhibitory concentration: 760 nM
Beside the measured number, compound 3's estimate is 11-fold (1.05 log units) above it; the whole stated range lies above it.
By their numbers in this assay, from the lowest: compound 1; then compound 3; then compound 2.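

In this assay, among the compounds shown here, a change that adds and removes no atoms still gives a 12-fold lower number from compound 2 to compound 3 (1.07 log units; beyond the scatter), so the drawn configuration at this saturated chain carbon cannot be treated as a detail of no consequence in this pair. The group swap also reads differently with the undefined drawing, which gives an 11-fold higher number from compound 1 to compound 3 (1.04 log units; beyond the scatter), a step beyond the scatter but clearly smaller than the one measured with the S drawing. The only difference on paper to which the gap within the diol pair can be traced is this: the fact that one of compounds 2 and 3 is drawn with a defined configuration and the other without, at the place where they differ.

As far as these compounds go, what remains open is what compound 3 holds, since a drawing without a configuration does not say which form or forms are present. Also open, from the compounds shown here alone, is how a carboxylic acid in place of the 2,3-dihydroxypropyl group would read here.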